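A few compounds are considered here, and "the series" means these few. Any claim that something is new, unique, unknown or untested is made for them only; others in the source may bear on it.

Measured in a functional assay for inhibition, with Homo sapiens as the target; a higher number here means a weaker inhibitor, a lower number a stronger inhibitor:
- Compound 1 `COC(=O)CCCCCCCCn1nc(-c2ccccc2)c(-c2ccccc2)c1-c1ccccc1`: 4300 nM
- Compound 2 `O=C(O)CCCCCCCCn1nc(-c2ccccc2)cc1-c1ccccc1`: > 66000 nM (a limit, not a number)

Compound 1 gives a true number, 4300 nM, so a reading can be obtained in this assay.

Compound 2 has no number at all, only the limit > 66000 nM. Its real value is therefore unknown, and any comparison with it has to stay loose.

Compound 3 `CCc1c(-c2ccccc2)nn(CCCCCCCCC(=O)O)c1-c1ccccc1` keeps the chain and the acid of compound 2 but has ethyl in place of hydrogen on an aromatic carbon. That carbon is next to two ring atoms that each bear a phenyl group.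

For the measured compounds named here, no measured pair here differs in one place only, so the size of this step has no direct precedent. A modest move towards stronger inhibition in this assay seems likely, though compound 3 could also end up as another limit. The lean towards a readable number rests only on compound 1 at 4300 nM, which is a weak guide.

The expected change is an at least 2.6-fold lower number from compound 2 to compound 3 (0.42 log units; beyond the scatter). For compound 3 the estimate is 25000 nM, with a range of 4000 nM to 100000 nM.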

Compound 3, half-maximal inhibitory concentration: > 79000 nM
Compound 3 was reported as a limit (the forecaster's own chance of this, stated with the estimate: 40%); middle value at least 3.1-fold (0.49 log units) away from the limit.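

For the compounds shown here, compound 2 and compound 3 are both reported only as limits in this assay, and no step between them can be read. The compounds shown leave open whether ethyl in place of hydrogen on an aromatic carbon changes inhibition at all in this assay.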